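Three Aryl Groups, and a Fourth Awaiting Its Number

A few compounds are considered here, and "the series" means these few. Any claim that something is new, unique, unknown or untested is made for them only; others in the source may bear on it.

Measured in a toxicity assay on MT4 cells (Homo sapiens) for cytotoxicity, read by MTT assay, with a stated time of 5 days; on this read-out higher numbers stand for lower toxicity in this test and lower numbers for higher toxicity in this test:
- compound 1 `Cc1cc(-c2ccco2)cc(C)c1Nc1ccnc(Nc2ccc(C#N)cc2)n1`: 1700 nM
- compound 2 `Cc1cc(-c2ccnc3ccccc23)cc(C)c1Nc1ccnc(Nc2ccc(C#N)cc2)n1`: 3500 nM
- compound 3 `Cc1cc(-c2ccc3cc[nH]c3c2)cc(C)c1Nc1ccnc(Nc2ccc(C#N)cc2)n1`: 5800 nM

Compound 3 belongs to the upper pair of these values. The data show a 1.7-fold higher number from compound 2 to compound 3 (0.22 log units; within the scatter), and they also show a 3.4-fold higher number from compound 1 to compound 3 (0.53 log units; beyond the scatter).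

The next compound, compound 4 `Cc1cc(-c2ccnc(F)c2)cc(C)c1Nc1ccnc(Nc2ccc(C#N)cc2)n1`, carries 2-fluoropyridin-4-yl in place of 1H-indol-6-yl on an aromatic carbon. Among the measured compounds shown here, no measured step makes this exact change, so the nearest guides are the other swaps at the same place. These were modest, with a 2.1-fold higher number from compound 1 to compound 2 (0.31 log units; beyond the scatter) alongside the step to compound 3 already given. Like furan-2-yl, the entering group is a single aromatic ring, and compound 1, with that group, gives 1700 nM. A modest step towards lower numbers, meaning higher toxicity, therefore seems likely in this assay. The expected step is a 2.3-fold lower number from compound 3 to compound 4 (0.37 log units; beyond the scatter). For compound 4 the estimated value is 2500 nM. The expected range for compound 4 runs from 800 nM to 8000 nM.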

Compound 4, half-maximal cytotoxic concentration: 6000 nM
Estimate against measurement, compound 4: 2.4-fold (0.38 log units) below; measured number inside the range.
By their numbers in this assay, from the lowest: compound 1; then compounds 2, 3 and 4 (each within the scatter of the next).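

The single ring of 2-fluoropyridin-4-yl does not bring the low number of furan-2-yl in this assay: it reads level with 1H-indol-6-yl, at a 1.0-fold higher number from compound 3 to compound 4 (0.01 log units; within the scatter), and with quinolin-4-yl, at a 1.7-fold higher number from compound 2 to compound 4 (0.23 log units; within the scatter), and this holds even though the hydrogen-bond donor of 1H-indol-6-yl leaves with the swap. Compound 1 alone stands apart, with a 3.5-fold higher number from compound 1 to compound 4 (0.55 log units; beyond the scatter), so a single aromatic ring at this position does not by itself go with a low number, and compound 4 goes against that idea. No measurement at hand explains why furan-2-yl differs from the other three groups.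

Still open, on these data alone, is whether thiophen-2-yl would read like furan-2-yl or like 2-fluoropyridin-4-yl. Also open, as far as these compounds go, is whether a group with no aromatic ring, such as an amine or a carboxylic acid, would keep the number at this level.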